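The source may report more compounds than this note shows. Statements on the series, on what has been measured and on what is new or still open speak of the compounds shown alone.

In a functional assay on THP-1 cells (Homo sapiens) for inhibition, read by ELISA, with stated times of 2 h and 48 h (on this read-out higher numbers stand for weaker inhibition and lower numbers for stronger inhibition), compound 3 (`CC(C)(C)/[N+]([O-])=C/c1cn(CCC(F)(F)C(F)(F)C(F)(F)C(F)(F)C(F)(F)C(F)(F)F)nn1`) gives 8100 nM. Compound 1 (`[O-]/[N+](=C\c1cn(CCC(F)(F)C(F)(F)C(F)(F)C(F)(F)C(F)(F)C(F)(F)C(F)(F)C(F)(F)F)nn1)c1ccccc1`) gives 11700 nM, which is within the usual scatter of compound 3, so those two cannot be told apart. Compound 2 (`[O-]/[N+](=C\c1cn(CCC(F)(F)C(F)(F)C(F)(F)C(F)(F)C(F)(F)C(F)(F)C(F)(F)C(F)(F)F)nn1)Cc1ccccc1`) gives 17000 nM, and that gap to compound 3 lies beyond the scatter, leaving compound 3 clearly the stronger inhibitor of that pair.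

Compound 4 (`CC(C)(C)/[N+]([O-])=C/c1cn(CCC(F)(F)C(F)(F)C(F)(F)C(F)(F)C(F)(F)C(F)(F)C(F)(F)C(F)(F)F)nn1`) differs from compound 3 in one place: 1,1,2,2,2-pentafluoroethyl in place of fluoro on a saturated chain carbon bound to two fluorine atoms and a saturated chain carbon. In words, 1,1,2,2,2-pentafluoroethyl stands in place of fluoro on a saturated chain carbon bound to two fluorine atoms and a saturated chain carbon, which lengthens the fluorinated chain.

For the measured compounds named here, no measured pair isolates this change. Going by the values given here, the only measured step, a 1.5-fold higher number from compound 1 to compound 2 (0.16 log units; within the scatter), lies elsewhere in the molecule and stays within the scatter. It does show that compound 1 and compound 2 both carry the longer chain of compound 4, and their values sit near or somewhat above that of compound 3. A small shift towards a higher number therefore seems likely, but nothing beyond the scatter. The expected change is a 1.3-fold higher number from compound 3 to compound 4 (0.11 log units; within the scatter) in this assay. For compound 4 the estimated value is 10500 nM, with an expected range of 5000 nM to 22000 nM.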

Compound 4, half-maximal inhibitory concentration: 15000 nM
Compound 4: the middle estimate sits 1.4-fold (0.15 log units) below what was measured, and the stated range covers the measured number.
By their numbers in this assay, from the lowest: compounds 3, 1, 4 and 2 (each within the scatter of the next, the first and the last beyond it).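

In this assay, for the compounds shown here, placing 1,1,2,2,2-pentafluoroethyl in place of fluoro on a saturated chain carbon bound to two fluorine atoms and a saturated chain carbon gives a 1.9-fold higher number from compound 3 to compound 4 (0.27 log units; within the scatter), the first direct reading of this change, and it shows that the longer fluorinated chain cannot be told apart from the shorter one by this measurement. With the longer chain kept the same, changing the group on the double-bonded nitrogen gives a 1.1-fold lower number from compound 2 to compound 4 (0.05 log units; within the scatter) for tert-butyl in place of benzyl and a 1.3-fold higher number from compound 1 to compound 4 (0.11 log units; within the scatter) for tert-butyl in place of phenyl , so tert-butyl cannot be separated from either of those groups at this chain length. No measurement offered here explains any of these numbers.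

Still open, going by these compounds, is whether a shorter fluorinated chain, or a plain hydrocarbon chain with no fluorine at all, would give a step larger than the usual scatter at this position. Also open, on these data alone, is whether a cyclohexyl group on the double-bonded nitrogen would stand apart from tert-butyl, phenyl and benzyl.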